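Chloro to Fluoro on the Benzamide: Expected Rat Half-Life

The source may report more compounds than this note shows. Statements on the series, on what has been measured and on what is new or still open speak of the compounds shown alone.

Compound 2 `CN1CCC(=C(F)c2cccc(NC(=O)c3ccc(Cl)cc3)n2)CC1` has been measured in an ADME assay on the whole organism (Rattus norvegicus, strain Sprague-Dawley) for metabolic stability, read by LC-MS, with a stated time of 24 h, at a dose of 1 mg/kg by the intravenous route (a higher number here means that the compound lasts longer, a lower number that the compound disappears faster), where compound 2 gives 1.6 h. Among the compounds with values here, of the two numbers known so far this is the highest, but the nearest one belongs to compound 1 `CN1CCC(=C(F)c2cccc(NC(=O)c3ccc(Cl)cc3F)n2)CC1`, which in this assay gives 1.42 h, and the two lie within the scatter of each other. Within the data shown here, the one step measured so far, a 1.1-fold higher number from compound 1 to compound 2 (0.05 log units; within the scatter), puts hydrogen in place of fluoro on an aromatic carbon and does nothing beyond the scatter.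

Compound 3 `CN1CCC(=C(F)c2cccc(NC(=O)c3ccc(F)cc3)n2)CC1` has not yet been measured. It differs from compound 2 by fluoro in place of chloro on an aromatic carbon: one halogen gives way to another on the six-membered aromatic ring of carbon only, para to a large group, so that 4-chlorophenyl becomes 4-fluorophenyl. Among the measured compounds shown here, no measured step touches this position, and the only step on record concerns another ring and stayed within the scatter. A halogen-for-halogen swap is therefore expected to move this assay little, if at all, and the expected step of a 1.1-fold lower number from compound 2 to compound 3 (0.03 log units; within the scatter) is small. For compound 3 the estimate in this assay is 1.5 h, with a range from 0.8 h to 2.8 h.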

Compound 3, half-life: 1.37 h
Estimate against measurement, compound 3: 1.1-fold (0.04 log units) above; the range from low to high includes it.
By their numbers in this assay, from the lowest: compounds 3, 1 and 2 (each within the scatter of the next).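

In this assay, within the data shown here, the exchange of 4-chlorophenyl for 4-fluorophenyl gives a 1.2-fold lower number from compound 2 to compound 3 (0.07 log units; within the scatter), so the position para to a large group now has a measured step of its own, whereas the earlier compounds offered a step at another place only. The wider exchange of 4-chloro-2-fluorophenyl for 4-fluorophenyl gives a 1.0-fold lower number from compound 1 to compound 3 (0.02 log units; within the scatter), which also lies within the scatter, and so the half-lives of all three compounds stand within the scatter of each other and the chloro and fluoro forms cannot be told apart by this read-out. No measurement at hand bears on the reason for this result.

The compounds shown carry only halogens at this position, so it remains open whether a methoxy group, a nitrile or an amine on the same aromatic carbon would stay within the scatter of these half-lives, or whether hydrogen there would do so. Also open, on these data alone, is whether the shared core, which is the same in all three compounds, would allow the same exchange to read alike if its methyl group gave way to a longer chain.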